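The compounds below may be only part of what the source reports. "The series", "measured", "known", "first", "only" and "open" are said of these compounds alone.

Measured in a functional assay on NCI-H661 cells (Homo sapiens) for antiproliferative activity, read by MTT assay, with a stated time of 72 h; a higher number here means a weaker inhibitor, a lower number a stronger inhibitor:
- compound 1 `Nc1ccccc1NC(=O)CCCCCCc1nc(-c2ccccc2)no1`: 960 nM
- compound 2 `Cc1ccc(-c2noc(CCCCCCC(=O)Nc3ccccc3N)n2)cc1`: 410 nM
- compound 3 `Nc1ccccc1NC(=O)CCCCCCc1nc(-c2cccc([N+](=O)[O-])c2)no1`: 7290 nM

Compound 1, at 960 nM, holds the second highest of the three numbers. Its two measured neighbours lie on either side of it, with a 2.3-fold lower number from compound 1 to compound 2 (0.37 log units; beyond the scatter) and a 7.6-fold higher number from compound 1 to compound 3 (0.88 log units; beyond the scatter).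

Compound 4 `O=C(CCCCCCc1nc(-c2ccccc2)no1)C(F)(F)F` differs from compound 1 in one place: trifluoromethyl in place of (2-aminophenyl)amino on a carbonyl carbon. Here trifluoromethyl stands in place of (2-aminophenyl)amino on a carbonyl carbon.

Among the measured compounds shown here, none of the measured steps touches that place. All three are changes on an aromatic carbon, and the widest is an 18-fold higher number from compound 2 to compound 3 (1.25 log units; beyond the scatter), so they offer only a rough scale for what a single change can do among these compounds. For the measured compounds named here, the data hold no compound that lacks the (2-aminophenyl)amino group, which leaves the direction a matter of expectation rather than of measurement. A higher number is expected in this assay, since this change is far larger than swapping one aromatic substituent, and a step of about the size seen for a 7.6-fold higher number from compound 1 to compound 3 (0.88 log units; beyond the scatter) seems reasonable. The expected step is a 5.2-fold higher number from compound 1 to compound 4 (0.72 log units; beyond the scatter). For compound 4 the estimated value is 5000 nM, with an expected range from 1200 nM to 20000 nM.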

Compound 4, half-maximal inhibitory concentration: 520 nM
The estimate for compound 4 lay 9.6-fold (0.98 log units) above the measured number; measured number outside the range, below it.
By their numbers in this assay, from the lowest: compounds 2, 4 and 1 (each within the scatter of the next, the first and the last beyond it); then compound 3.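

In this assay, among the compounds shown here, the first change at this carbonyl carbon gives a 1.8-fold lower number from compound 1 to compound 4 (0.27 log units; within the scatter), so replacing (2-aminophenyl)amino, with its six-membered aromatic ring and hydrogen-bond donors, by trifluoromethyl produces no difference that these measurements can resolve. For this pair, then, a number in the same range does not require the (2-aminophenyl)amino group, even though a single substituent change on an aromatic carbon can give a clear shift, as in a 7.6-fold higher number from compound 1 to compound 3 (0.88 log units; beyond the scatter). No evidence is available to explain why such different groups give numbers within the scatter of each other.

The compounds shown leave open whether other groups on this carbonyl carbon, such as a hydroxyamino group or a plain methyl, would also fall in this range, and whether trifluoromethyl would give a similar result in place of (2-aminophenyl)amino on compound 2, with its 4-methylphenyl group, or on compound 3, with its 3-nitrophenyl group. They also leave open how a shorter or longer saturated chain would affect the result with either group on the carbonyl carbon.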